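Working notes: compound 2 to compound 3

This account rests on a few compounds, and the source may have more. Where it says the series, first, only, none or still open, it means among the compounds named here.

In a functional assay on IMR-32 cells (Homo sapiens) for cytotoxicity, read by sulforhodamine B assay, with a stated time of 48 h (on this read-out lower numbers stand for stronger inhibition and higher numbers for weaker inhibition), compound 1 `COc1cc(C2CC(c3ccc(Br)cc3)=NN2C(C)=O)cc(OC)c1OC` gives 3130 nM, while compound 2 `O=CCN1N=C(c2ccc3ccccc3c2)CC1c1cccc(Cl)c1Cl` gives 16900 nM, the higher of the two numbers and beyond the scatter from compound 1. Compound 3 `O=CCN1N=C(c2ccc3ccccc3c2)CC1/C=C/c1ccccc1` differs from compound 2 by 2-phenylethenyl in place of 2,3-dichlorophenyl on a saturated ring carbon. Within the data shown here, no measured pair isolates this change, so the numbers at hand give no size for it. For compound 3 a step within the scatter, in either direction, is expected, a 1.4-fold lower number from compound 2 to compound 3 (0.15 log units; within the scatter). Compound 3 is accordingly estimated at 12000 nM, with a range from 4000 nM to 40000 nM.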

Compound 3, half-maximal inhibitory concentration: 17200 nM
Compound 3: middle estimate off by 1.4-fold (0.16 log units), on the low side, within the range that was stated.
By their numbers in this assay, from the lowest: compound 1; then compounds 2 and 3 (each within the scatter of the next).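

In this assay, the step for 2-phenylethenyl in place of 2,3-dichlorophenyl on a saturated ring carbon is a 1.0-fold higher number from compound 2 to compound 3 (0.01 log units; within the scatter) and gives the first measured size for a change at this position. Here a group without chlorine and with a double bond outside aromatic rings stands in for the dichlorinated ring, and the two numbers remain within the scatter of each other. No evidence at hand bears on this result.

Open, as far as these compounds go, is whether 2-phenylethyl, an amine or a carboxylic acid on this ring carbon would give a step beyond the scatter.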